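Compound 4: swapping methoxy for cyano

The compounds below may be only part of what the source reports. "The series", "measured", "known", "first", "only" and "open" are said of these compounds alone.

Measured in a functional assay on Huh-5-2 cells (Homo sapiens), read by MTT assay; a higher number here means that more compound is tolerated, a lower number that less compound is tolerated:
- Compound 1 `NC(=O)c1ccc(-c2ccc(Cl)cc2COc2ccc(-c3nc4cc(C(=O)O)ccc4n3C3CCCCC3)cc2)cc1`: > 50000 nM, which is a limit of the assay
- Compound 2 `O=C(O)c1ccc2c(c1)nc(-c1ccc(OCc3ccccc3-c3ccc(Cl)cc3)cc1)n2C1CCCCC1`: 25000 nM
- Compound 3 `COc1ccc(-c2ccc(Cl)cc2)c(COc2ccc(-c3nc4cc(C(=O)O)ccc4n3C3CCCCC3)cc2)c1`: 24000 nM

Going by the values given here, compound 3 lies within the scatter of compound 2, the only other compound with an exact number. Compound 4 `N#Cc1ccc(-c2ccc(Cl)cc2)c(COc2ccc(-c3nc4cc(C(=O)O)ccc4n3C3CCCCC3)cc2)c1` carries cyano in place of methoxy on an aromatic carbon, para to a 4-chlorophenyl group (cyano in place of methoxy on an aromatic carbon). Among the compounds with values here, one measured step bears on this carbon. Putting methoxy there in place of hydrogen gave a 1.0-fold lower number from compound 2 to compound 3 (0.02 log units; within the scatter). Since that change made no measurable difference, no shift beyond the scatter is expected in this assay for this swap. The expected change is a 1.0-fold higher number from compound 3 to compound 4 (0.02 log units; within the scatter). For compound 4 the estimated value is 25000 nM, with an expected range of 12000 nM to 50000 nM.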

Compound 4, half-maximal cytotoxic concentration: 23000 nM
For compound 4 the middle estimate is 1.1-fold (0.04 log units) above the measured one; the range from low to high includes it.
By their numbers in this assay, from the lowest: compounds 4, 3 and 2 (each within the scatter of the next). At a limit, above all of these: compound 1.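

In this assay, swapping methoxy for cyano on this aromatic carbon, para to a 4-chlorophenyl group, gives a 1.0-fold lower number from compound 3 to compound 4 (0.02 log units; within the scatter) and putting cyano in place of hydrogen gives a 1.1-fold lower number from compound 2 to compound 4 (0.04 log units; within the scatter) as well. Hydrogen, methoxy and cyano on this carbon therefore all lie within the scatter of one another, so a second substituent here now also leaves the number unmoved. Nothing on hand explains this result. Still open, on these data alone, is whether an amine, a carboxylic acid or a longer chain on this carbon would leave the number just as unmoved.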